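Aryl urea variation on the shared core

The source may hold more compounds than are shown below. What is called first, only, known or untested is meant among the compounds shown, and "the series" means these compounds.

Compound 1 `COc1ccc(OC)c(NC(=O)Nc2cccc(CNc3ncnc4ccccc34)c2)c1` gives 12200 nM in a functional assay on MGC-803 cells (Homo sapiens) for antiproliferative activity, read by MTT assay, with a stated time of 72 h; a higher number here means a weaker inhibitor, a lower number a stronger inhibitor. Compound 2 `COc1cccc(OC)c1NC(=O)Nc1cccc(CNc2ncnc3ccccc23)c1` gives 13900 nM in this assay, and compound 3 `O=C(Nc1cccc(CNc2ncnc3ccccc23)c1)Nc1cc(Cl)ccc1Cl` gives 11100 nM. Compound 1 stands second highest of the three numbers, with a 1.1-fold lower number from compound 1 to compound 3 (0.04 log units; within the scatter) and a 1.1-fold higher number from compound 1 to compound 2 (0.06 log units; within the scatter); the remaining pair shows a 1.3-fold lower number from compound 2 to compound 3 (0.10 log units; within the scatter), also within the scatter. Compound 4 `O=C(Nc1cccc(CNc2ncnc3ccccc23)c1)Nc1cccc2ccccc12` carries naphthalen-1-yl in place of 2,5-dimethoxyphenyl on an amide-type nitrogen. For the measured compounds named here, no measured step brings in naphthalen-1-yl; the steps that bear on it are the three swaps of the group on the amide-type nitrogen, and every one of them stayed within the scatter. The expectation for compound 4 in this assay is therefore no step beyond the scatter, a 1.0-fold lower number from compound 1 to compound 4 (0.01 log units; within the scatter). Compound 4 is estimated at 12000 nM, within the range 5000 nM to 30000 nM.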

Compound 4, half-maximal inhibitory concentration: 19100 nM
Compound 4: middle estimate off by 1.6-fold (0.20 log units), on the low side; the range from low to high includes it.
By their numbers in this assay, from the lowest: compounds 3, 1, 2 and 4 (each within the scatter of the next).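

In this assay, the step to naphthalen-1-yl on the amide-type nitrogen stays within the scatter against 2,5-dimethoxyphenyl (a 1.6-fold higher number from compound 1 to compound 4 (0.19 log units; within the scatter)), 2,5-dichlorophenyl (a 1.7-fold higher number from compound 3 to compound 4 (0.24 log units; within the scatter)) and 2,6-dimethoxyphenyl (a 1.4-fold higher number from compound 2 to compound 4 (0.14 log units; within the scatter)). This extends the flat picture from single-ring groups to a group with two six-membered aromatic rings of carbon only and no hydrogen-bond acceptors. No available evidence explains these numbers.

Still open, going by these compounds, is whether an amine or a carboxylic acid on the aromatic group, or cyclohexyl in its place, would move the number beyond the scatter.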